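Ring Size on the Ester Chain and Receptor Inhibition

The compounds below may be only part of what the source reports. "The series", "measured", "known", "first", "only" and "open" are said of these compounds alone.

Compound 1, `CCC(C)OC(=O)C1=C(C)NC(=O)NC1c1ccsc1`, in an assay on membranes from CHO cells for displacement of a labelled ligand from adenosine receptor A1 (Homo sapiens), read by scintillation counting, with a stated time of 60 min, tested at 1 uM (a higher number here means more inhibition at the concentration tested (going by the name of the read-out), a lower number less inhibition), gives 5%.
Compound 2, `CC1=C(C(=O)OCC2CC2)C(c2ccsc2)NC(=O)N1`, in this assay gives 39%.

Compound 2 holds the higher of the two numbers measured; its nearest neighbour is compound 1, and the step of a number 34 percentage points higher from compound 1 to compound 2 (beyond the scatter) lies beyond the scatter. Compound 3, `CC1=C(C(=O)OCC2CCC2)C(c2ccsc2)NC(=O)N1`, has not yet been measured. It differs from compound 2 by cyclobutyl in place of cyclopropyl on a saturated chain carbon bound to an oxygen next to a carbonyl group. For the measured compounds named here, the only measured step concerns the same place, the chain on the oxygen next to the carbonyl group, and was large, so the group there clearly matters. Yet the change here is modest: one ring carbon more. Compound 3 is therefore expected to stay close to compound 2, with the step of a number 1 percentage points higher from compound 2 to compound 3 (within the scatter) likely within the scatter, in either direction. The estimate for compound 3 in this assay is 40%, within a range from 15% to 65%.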

Compound 3, a percentage reported as inhibition, at one concentration (the size of the read-out at that concentration, not a potency): 48%
Compound 3: middle estimate off by 8 percentage points, on the low side; low and high end bracket the measured number.
By their numbers in this assay, from the lowest: compound 1; then compounds 2 and 3 (each within the scatter of the next).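

In this assay the move to the larger ring (a number 9 percentage points higher from compound 2 to compound 3 (within the scatter)) shows that cyclopropyl and cyclobutyl on this saturated chain carbon cannot be told apart, so this position accepts either ring. Set against the open-chain sec-butyl group, cyclobutylmethyl also brings a clear rise (a number 43 percentage points higher from compound 1 to compound 3 (beyond the scatter)), so the large step seen earlier is not tied to the three-membered ring alone. No measurement shown here explains why both ring-bearing chains stand apart from sec-butyl.

Still open, going by these compounds, is whether a larger ring on the same carbon, such as cyclopentyl or cyclohexyl, would keep this level of inhibition. It is equally unclear whether a straight n-butyl chain would behave like the ring-bearing chains or like sec-butyl.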